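This account rests on a few compounds, and the source may have more. Where it says the series, first, only, none or still open, it means among the compounds named here.

Compound 1 `COc1cc(-c2ccnc3cc(-c4ccc(C)cc4)nn23)cc(OC)c1OC`: 47 nM
Compound 2 `COc1cc(-c2ccnc3cc(-c4ccc(C)c(C)c4)nn23)cc(OC)c1OC`: 26 nM
Compound 3 `COc1cc(-c2ccnc3cc(-c4ccc(N(C)C)cc4)nn23)cc(OC)c1OC`: 44 nM

Of the compounds shown here, three built on one shared core have been tested in a functional assay on MCF7 cells (Homo sapiens) for inhibition, read by CCK-8 assay, with a stated time of 48 h; a lower number here means a stronger inhibitor, a higher number a weaker inhibitor. Compound 1 gives 47 nM, the highest of the three numbers, yet its gaps to compound 3 and to compound 2 both lie within the scatter, so no order among them can be read. The two steps away from compound 1 are a 1.8-fold lower number from compound 1 to compound 2 (0.26 log units; within the scatter) and a 1.1-fold lower number from compound 1 to compound 3 (0.03 log units; within the scatter); between the other two, a 1.7-fold higher number from compound 2 to compound 3 (0.23 log units; within the scatter). Each of these steps alters only a group on an aromatic carbon of the six-membered aromatic ring of carbon only, and none of them moves the number beyond the scatter.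

Compound 4 `C=Cc1ccc(-c2cc3nccc(-c4cc(OC)c(OC)c(OC)c4)n3n2)cc1` has not yet been measured. It differs from compound 1 as follows: vinyl in place of methyl on an aromatic carbon. Among the measured compounds shown here, the steps that bear on it are those that change the same ring, namely a 1.8-fold lower number from compound 1 to compound 2 (0.26 log units; within the scatter) and a 1.1-fold lower number from compound 1 to compound 3 (0.03 log units; within the scatter), both small. Nothing in these data shows that vinyl acts differently from methyl or dimethylamino at this aromatic carbon, so the expected step is a 1.0-fold lower number from compound 1 to compound 4 (0.02 log units; within the scatter), with no change beyond the scatter. Compound 4 is therefore estimated at 45 nM, with a range from 20 nM to 100 nM.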

Compound 4, half-maximal inhibitory concentration: 193 nM
The estimate for compound 4 lay 4.3-fold (0.63 log units) below the measured number; the measured number lies above the stated range.
By their numbers in this assay, from the lowest: compounds 2, 3 and 1 (each within the scatter of the next); then compound 4.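

In this assay, the aromatic carbon para to a large group turns out not to be indifferent to what it carries: a 4.1-fold higher number from compound 1 to compound 4 (0.61 log units; beyond the scatter), and a 4.4-fold higher number from compound 3 to compound 4 (0.64 log units; beyond the scatter), although methyl and dimethylamino at this carbon could not be told apart. The widest gap is a 7.4-fold higher number from compound 2 to compound 4 (0.87 log units; beyond the scatter), which sets compound 4 apart from all three earlier compounds and makes it the weakest of the four, so a change as small as 4-methylphenyl to 4-vinylphenyl, adding one carbon and one double bond outside aromatic rings, is enough to move the number beyond the scatter. No measurement at hand says what lies behind this rise.

On these data alone, whether the higher number goes with the double bond or with the second carbon remains open, and an ethyl group at this carbon would separate the two. As far as these compounds go, how other groups would read here, such as methoxy, a primary amine or a longer chain, also remains open, as does whether vinyl would give a similar step alongside the second methyl of compound 2.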